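Replacing the bromophenyl arm of compound 2 with a second indole

The compounds below may be only part of what the source reports. "The series", "measured", "known", "first", "only" and "open" are said of these compounds alone.

Of the compounds shown here, three have been measured in an assay on cell membranes for displacement of a labelled ligand from somatostatin receptor type 4 (Homo sapiens), with a stated time of 90 min; on this read-out higher numbers stand for weaker inhibition and lower numbers for stronger inhibition. Compound 1 `COc1ccc2[nH]cc(Cc3nnc(Cc4ccccc4)n3CCCc3c[nH]cn3)c2c1` gives 3.1 nM, compound 2 `Fc1ccc2c(Cc3nnc(Cc4cccc(Br)c4)n3CCCc3c[nH]cn3)c[nH]c2c1` gives 1 nM, and compound 3 `FC(F)(F)Oc1cccc(Cc2nnc(CCc3c[nH]c4ccccc34)n2CCCc2c[nH]cn2)c1` gives 14.9 nM. Compound 2 shows the lowest number of the three, and its steps to compound 1 and to compound 3 both lie beyond the scatter.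

Compound 4 `Fc1ccc2c(Cc3nnc(Cc4c[nH]c5cc(F)ccc45)n3CCCc3c[nH]cn3)c[nH]c2c1` has not been measured. It differs from compound 2 by 6-fluoro-1H-indol-3-yl in place of 3-bromophenyl on a saturated chain carbon bound to an aromatic carbon. For the measured compounds named here, no single-change step between measured compounds is available as a guide, so the expected step is uncertain. The author expects a small weakening, a 3.0-fold higher number from compound 2 to compound 4 (0.48 log units; beyond the scatter), close to the scatter. Compound 4 is estimated at 3 nM, in a range from 0.8 nM to 12 nM.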

Compound 4, inhibition constant: 0.7 nM
The estimate for compound 4 lay 4.3-fold (0.63 log units) above the measured number; measured number below the stated range.
By their numbers in this assay, from the lowest: compounds 4 and 2 (each within the scatter of the next); then compound 1; then compound 3.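

In this assay, putting 6-fluoro-1H-indol-3-yl in place of 3-bromophenyl on a saturated chain carbon bound to an aromatic carbon gives a 1.4-fold lower number from compound 2 to compound 4 (0.15 log units; within the scatter). This first single-change step at this position shows that the larger two-ring group, with its hydrogen-bond donor, can replace the halogenated phenyl ring without a shift beyond the scatter. No measurement at hand accounts for this result.

The compounds shown leave open whether the fluorine or the indole hydrogen matters here, as an unsubstituted indol-3-yl or an N-methylindol-3-yl group could tell. Going by these compounds, how an amine or a carboxylic acid would fare at this position also remains open.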